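Swapping 2-methoxybutyl for (furan-3-yl)carbonyl on one oxygen

A few compounds are considered here, and "the series" means these few. Any claim that something is new, unique, unknown or untested is made for them only; others in the source may bear on it.

In a functional assay on DU-145 cells (Homo sapiens) for cytotoxicity, read by MTT assay (a higher number here means a weaker inhibitor, a lower number a stronger inhibitor), compound 3 `CCC(CO[C@H](CC=C(C)C)C1=CC(=O)c2c(O)ccc(O)c2C1=O)OC` gives 45700 nM and so sits level with compound 1 `CC(C)=CC[C@@H](OC(=O)C1CCOC1)C1=CC(=O)c2c(O)ccc(O)c2C1=O` at 47500 nM within the scatter. Compound 2 `CC(C)=CC[C@@H](OC(=O)CC(C)(O)c1ccccc1)C1=CC(=O)c2c(O)ccc(O)c2C1=O` gives > 100000 nM as a limit of the assay and not a number.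

Compound 4 `CC(C)=CC[C@@H](OC(=O)c1ccoc1)C1=CC(=O)c2c(O)ccc(O)c2C1=O` differs from compound 3 by the change (furan-3-yl)carbonyl in place of 2-methoxybutyl on an oxygen on a saturated carbon and in short this is (furan-3-yl)carbonyl in place of 2-methoxybutyl on an oxygen on a saturated carbon.

For the measured compounds named here, two measured steps bear on this change. The first, a 1.0-fold lower number from compound 1 to compound 3 (0.02 log units; within the scatter) puts 2-methoxybutyl in place of (oxolan-3-yl)carbonyl on that same kind of oxygen and stays within the scatter. The second, an at least 2.1-fold higher number from compound 1 to compound 2 (0.32 log units; beyond the scatter) puts 2-hydroxy-2-phenylpropyl in place of oxolan-3-yl on a carbonyl carbon and goes beyond the scatter, so the upper end of the range has to stay wide. The first step is the closer guide, so a shift beyond the scatter is not expected for compound 4.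

The estimated step is a 1.1-fold lower number from compound 3 to compound 4 (0.06 log units; within the scatter) and so no real change is expected in this assay here. For compound 4 the estimated value is 40000 nM with an expected range of 15000 nM to 100000 nM in this measurement.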

Compound 4, half-maximal inhibitory concentration: > 100000 nM
Compound 4: a limit, no number; the forecaster's own chance of this, stated with the estimate: 15%; at least 2.5-fold (0.39 log units) between middle value and limit.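

In this assay compound 4 gives > 100000 nM, which is a limit of the assay and not a number. The earlier compounds shown here left 2-methoxybutyl and (oxolan-3-yl)carbonyl level with each other on this oxygen, which could suggest that the position tolerates quite different groups, but (furan-3-yl)carbonyl breaks from both, with an at least 2.1-fold higher number from compound 3 to compound 4 (0.34 log units; beyond the scatter) and an at least 2.1-fold higher number from compound 1 to compound 4 (0.32 log units; beyond the scatter). The second of these steps is the more telling, since only the five-membered ring changes, from oxolan-3-yl to furan-3-yl, so the position responds even to a small change in that ring, although the step between compound 2 and compound 4 cannot be read and the other two steps give only a minimum size, because the values of compound 2 and compound 4 are limits: the limit of > 100000 nM in this assay, at which 2 of the 4 values shown sit.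

As far as these compounds go, how far compound 4 really lies past that limit stays open. Also open, from the compounds shown here alone, is whether another aromatic ring on the carbonyl, such as thiophen-3-yl, would behave like furan-3-yl, or whether a six-membered saturated ring such as oxan-4-yl would stay level with oxolan-3-yl.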